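A few compounds are considered here, and "the series" means these few. Any claim that something is new, unique, unknown or untested is made for them only; others in the source may bear on it.

Compound 1 `Cc1ccc2nc(N3CCCc4ccc(F)cc4C3)cc(NCC3(N)COC3)c2c1`: in an ADME assay on HEp-2 cells (Homo sapiens) for cytotoxicity, read by CCK-8 assay, with a stated time of 5 days (on this read-out higher numbers stand for lower toxicity in this test and lower numbers for higher toxicity in this test), compound 1 reaches only the limit > 100000 nM, not a number.
Compound 2 `NCC(O)CNc1cc(N2CCc3ccccc3C2)nc2ccccc12`: in this assay compound 2 gives 21000 nM.
Compound 3 `OCC(O)CNc1cc(N2CCc3ccccc3C2)nc2ccccc12`: in this assay compound 3 gives 66000 nM.

Compound 1 therefore stands at a limit of this assay; it is one of the values covered by the limit of > 100000 nM in this assay, at which 1 of the 3 values shown sits, so its distance from compounds 2 and 3 is not fixed by the numbers shown. The step to compound 4 `Cc1ccc2nc(N3CCCc4ccc(F)cc4C3)cc(NC(C)CN)c2c1` is 1-(aminomethyl)ethyl in place of (3-aminooxetan-3-yl)methyl on a nitrogen on an aromatic ring. Among the measured compounds shown here, no measured step makes this same change. For the measured compounds named here, the only measured step, a 3.1-fold higher number from compound 2 to compound 3 (0.50 log units; beyond the scatter), swaps a primary amine for a hydroxy on a different core and so speaks to the role of the amine rather than to the loss of the oxetane ring; compound 4 keeps a primary amine, as compound 2 does with its 21000 nM. Since compound 1 gives only a limit, the size of the step cannot be read from compound 1 itself, but compound 4 is expected to fall back into the measurable range, so a downward step an at least 2.0-fold lower number from compound 1 to compound 4 (0.30 log units; that floor lies within the scatter) is expected. Compound 4 is estimated at 50000 nM, with a range from 15000 nM to 150000 nM.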

Compound 4, half-maximal cytotoxic concentration: 25000 nM
The estimate for compound 4 lay 2.0-fold (0.30 log units) above the measured number, and the stated range covers the measured number.
By their numbers in this assay, from the lowest: compounds 2 and 4 (each within the scatter of the next); then compound 3. At a limit, above all of these: compound 1.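

In this assay, 1-(aminomethyl)ethyl in place of (3-aminooxetan-3-yl)methyl on a nitrogen on an aromatic ring gives an at least 4.0-fold lower number from compound 1 to compound 4 (0.60 log units; beyond the scatter). This is the first step shown at this position on the core of compound 1, and unlike the earlier swap of hydroxy for amino on another core, it keeps a primary amine on both sides, so the number moves beyond the scatter with the amine still in place and the four-membered ring gone. The step stands only as a floor, because compound 1 sits at a limit: the limit of > 100000 nM in this assay, at which 1 of the 4 values shown sits.

The compounds shown leave open whether the step follows the loss of the oxetane ring or the methyl branch of the new chain, a question that an unbranched 2-aminoethyl group or a cyclobutane ring on the same nitrogen would bear on. Also open, as far as these compounds go, is whether a hydroxy in place of the amine would raise the number on this core as it does in a 3.1-fold higher number from compound 2 to compound 3 (0.50 log units; beyond the scatter).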